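A few compounds are considered here, and "the series" means these few. Any claim that something is new, unique, unknown or untested is made for them only; others in the source may bear on it.

Compounds measured so far in a functional assay on CCRF-CEM cells (Homo sapiens) for inhibition; a higher number here means a weaker inhibitor, a lower number a stronger inhibitor:
compound 1, `CCC(C)C1NC(=O)N(C2CCCC2)C1=O` — > 200000 nM
compound 2, `CC(C)C1NC(=O)N(C2CCCC2)C1=O` — > 200000 nM

In this assay compound 1 gives > 200000 nM, which is a limit of the assay and not a number. In this assay compound 2 gives > 200000 nM, likewise a limit. Going by the values given here, the single measured step, a step that the two limits leave unreadable from compound 1 to compound 2, is therefore of unreadable size, and compound 2 stands only at that limit, with no number to place it. The unmeasured compound 3, `O=C1NC(c2ccccc2)C(=O)N1C1CCCC1`, differs from compound 2 by phenyl in place of isopropyl on a saturated ring carbon. Among the compounds with values here, no measured step bears on this change, and the only evidence available is the limit of > 200000 nM in this assay, at which 2 of the 2 values shown sit, so neither a size nor a direction for the step in this assay can be read from the data. Compound 3 is expected to give 200000 nM, with a range from 40000 nM to 1000000 nM. This corresponds to an expected step of a number no higher from compound 2 to compound 3 (the limit leaves the size open), most likely again reported as a limit.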

Compound 3, half-maximal inhibitory concentration: > 200000 nM
Compound 3 was reported as a limit; the forecaster's own chance of this, stated with the estimate: 75%; the middle value lies on the limit itself.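

In this assay compound 3 gives > 200000 nM, again a limit of the assay and not a number, so no new step can be read among compound 1, compound 2 and compound 3. The compounds shown leave open whether any group at this place on the shared core gives a readable value: the limit of > 200000 nM in this assay, at which 3 of the 3 values shown sit.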